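Triazole aryl swap on the butenolide series: hydroxyphenyl to methylphenyl

A few compounds are considered here, and "the series" means these few. Any claim that something is new, unique, unknown or untested is made for them only; others in the source may bear on it.

Working notes on the series. Compound 1 `O=C1O[C@H]([C@@H](O)Cn2cc(-c3cccc(O)c3)nn2)C(OCc2ccccc2)=C1OCc1ccccc1` is the comparator. Within the data shown here, in a functional assay on CFPAC-1 cells (Homo sapiens) for antiproliferative activity, read by MTT assay, with a stated time of 72 h (a higher number here means a weaker inhibitor, a lower number a stronger inhibitor), compound 1 gives 54100 nM, the highest of the two numbers so far. Compound 2 `O=C1O/C(=C\Cn2cc(-c3cccc(O)c3)nn2)C(OCc2ccccc2)=C1OCc1ccccc1`, the olefinic analogue of the shared core, gives 33700 nM in this assay; the two values lie within the scatter of each other, so no order between compound 1 and compound 2 is claimed.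

Compound 3 `Cc1ccc(-c2cn(C[C@H](O)[C@H]3OC(=O)C(OCc4ccccc4)=C3OCc3ccccc3)nn2)cc1` is the next member to be measured in this assay. It differs from compound 1 in one place: 4-methylphenyl in place of 3-hydroxyphenyl on an aromatic carbon. Among the measured compounds shown here, no measured pair shows this change, so no step can be read from the data for it. Both measured values sit in the same weak region, which gives no direction to expect beyond the scatter.

Compound 3 is therefore expected to stay close to compound 1, with an expected step of a 1.1-fold lower number from compound 1 to compound 3 (0.03 log units; within the scatter) not beyond the scatter. The estimate for compound 3 in this assay is 50000 nM, within a range from 20000 nM to 125000 nM.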

Compound 3, half-maximal inhibitory concentration: > 100000 nM
Compound 3: no number, only a limit (the forecaster's own chance of this, stated with the estimate: 20%); at least 2.0-fold (0.30 log units) between middle value and limit.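

Compound 3 carries a limit of the assay in this assay and not a number: the limit of > 100000 nM in this assay, at which 1 of the 3 values shown sits.

Read against compound 1, this gives the first step at this place, on an aromatic carbon of the five-membered aromatic ring with 3 nitrogen: an at least 1.8-fold higher number from compound 1 to compound 3 (0.26 log units; that floor lies within the scatter). As far as these compounds go, only a floor is known for this step, so its true size stays unknown, and no order between the two compounds is claimed from it. What the step does add is narrow: with 4-methylphenyl in place of 3-hydroxyphenyl, this assay gives no sign of a lower number, so this swap offers no route out of the weak region in which the earlier values sit.

The change alters both the substituent and where it sits on the phenyl ring, and the compounds shown do not separate the two, which 4-hydroxyphenyl or 3-methylphenyl on the same core would do. Also open, from the compounds shown here alone, is how this position responds to a phenyl ring bearing an amine or a carboxylic acid, or to a longer chain between the triazole and the aryl group.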